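A few compounds are considered here, and "the series" means these few. Any claim that something is new, unique, unknown or untested is made for them only; others in the source may bear on it.

In a functional assay (plasma) with Oryctolagus cuniculus as the target (a lower number here means a stronger inhibitor, a higher number a weaker inhibitor), compound 1 `Cc1nc2cnccc2n1CC1CCN(C(=O)CC(C)c2ccccc2)CC1` gives 12 nM. For the measured compounds named here, its only measured neighbour is compound 2 `CCCC(CC(=O)N1CCC(Cn2c(C)nc3cnccc32)CC1)c1ccccc1` at 11 nM, and these two values lie within the scatter of each other. Compound 3 `Cc1nc2cnccc2n1CC1CCN(C(=O)N[C@@H](C)c2ccccc2)CC1` alters compound 1 at a different kind of point: (1-phenylethyl)amino in place of 2-phenylpropyl on a carbonyl carbon. In words, (1-phenylethyl)amino stands in place of 2-phenylpropyl on a carbonyl carbon whose other neighbour is an amide-type nitrogen in a ring.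

Going by the values given here, only one measured step offers any guidance, and it is a 1.1-fold lower number from compound 1 to compound 2 (0.04 log units; within the scatter). That step places ethyl in place of hydrogen on a saturated chain carbon and stays within the scatter. Among the compounds with values here, it retains the carbon chain, whereas compound 3 exchanges 2-phenylpropyl for an amino-linked group, and no measured compound shows the effect of such an exchange. The small step therefore gives only weak support, and the size of the new step remains uncertain. A moderate move towards a higher number in this assay is expected, with a wide margin. The estimate means a 2.1-fold higher number from compound 1 to compound 3 (0.32 log units; beyond the scatter). For compound 3 the expected value is 25 nM, with an estimated range from 5 nM to 120 nM.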

Compound 3, half-maximal inhibitory concentration: 41 nM
Compound 3: middle estimate off by 1.6-fold (0.21 log units), on the low side; the range from low to high includes it.
By their numbers in this assay, from the lowest: compounds 2 and 1 (each within the scatter of the next); then compound 3.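

In this assay, the position on the carbonyl carbon whose other neighbour is an amide-type nitrogen in a ring proves sensitive to a change in the link to the phenyl ring, something the earlier pair could not show, since ethyl in place of hydrogen on the chain gave only a 1.1-fold lower number from compound 1 to compound 2 (0.04 log units; within the scatter), within the scatter, while (1-phenylethyl)amino in place of 2-phenylpropyl gives a 3.4-fold higher number from compound 1 to compound 3 (0.53 log units; beyond the scatter), a modest loss beyond the scatter. The two groups have the same count of heavy atoms and the same six-membered aromatic ring of carbon only, yet the entering group also brings a nitrogen, a hydrogen-bond donor and a defined stereocentre, so this single step reads all of these differences together. Nothing measured here explains the loss.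

As far as these compounds go, what stays open is which of these differences carries the step, and a 1-phenylethoxy group on the same carbonyl carbon, a methyl on the amino nitrogen or the opposite stereocentre would each bear on that question. From the compounds shown here alone, it is also open whether the flat result for ethyl on the chain would hold for the amino-linked group, as in (1-phenylbutyl)amino.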